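A few compounds are considered here, and "the series" means these few. Any claim that something is new, unique, unknown or untested is made for them only; others in the source may bear on it.

Measured compounds:
Compound 1 `CCCCC(O)CC(=O)O[C@H](CC=C(C)C)C1=CC(=O)c2c(O)ccc(O)c2C1=O` gives 45300 nM in a functional assay on DU-145 cells (Homo sapiens) for cytotoxicity, read by MTT assay; on this read-out higher numbers stand for weaker inhibition and lower numbers for stronger inhibition.
Compound 2 `CC(=O)OCCO[C@H](CC=C(C)C)C1=CC(=O)c2c(O)ccc(O)c2C1=O` gives 15500 nM in this assay.
Compound 3 `CC(C)=CC[C@@H](OC(=O)CC(C)(O)c1ccccc1)C1=CC(=O)c2c(O)ccc(O)c2C1=O` reaches only a limit of the assay, > 100000 nM in this assay.

Among the numbers shown, compound 2 has the lowest, and its nearest neighbour is compound 1: a 2.9-fold lower number from compound 1 to compound 2 (0.47 log units; beyond the scatter). The value of compound 3 is one of those sitting at the limit of > 100000 nM in this assay, at which 1 of the 3 values shown sits, so it is a limit and not a number.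

Compound 4 `CC(C)=CC[C@@H](OC(=O)c1ccoc1)C1=CC(=O)c2c(O)ccc(O)c2C1=O` differs from compound 2 in one place: (furan-3-yl)carbonyl in place of 2-acetoxyethyl on an oxygen on a saturated carbon. Of the measured steps, a 2.9-fold lower number from compound 1 to compound 2 (0.47 log units; beyond the scatter) touches the same oxygen, swapping an ester for an ether, and an at least 2.2-fold higher number from compound 1 to compound 3 (0.34 log units; beyond the scatter) alters only the chain of the ester. Among the measured compounds shown here, neither is the same change as the one to compound 4, and both are modest in size, so the expectation is loose. Compound 4 is estimated at 30000 nM, with a range from 8000 nM to 100000 nM. That estimate means a 1.9-fold higher number from compound 2 to compound 4 (0.29 log units; within the scatter) is expected, a slight weakening in line with the ester of compound 1.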

Compound 4, half-maximal inhibitory concentration: > 100000 nM
Compound 4: a limit, no number; the forecaster's own chance of this, stated with the estimate: 20%; middle value at least 3.3-fold (0.52 log units) from the limit.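

Replacing 2-acetoxyethyl with (furan-3-yl)carbonyl on this oxygen weakens the effect in this assay, with an at least 6.4-fold higher number from compound 2 to compound 4 (0.80 log units; beyond the scatter). Among the esters, furan-3-yl on the carbonyl carbon also does worse than the 2-hydroxyhexyl chain, with an at least 2.2-fold higher number from compound 1 to compound 4 (0.34 log units; beyond the scatter), so a ring in the ester group now goes with a loss in two compounds, not just in compound 3. The value of compound 4 is a limit, the step from compound 3 cannot be read, and the two ring-bearing esters cannot be ranked, as both sit at the same ceiling: the limit of > 100000 nM in this assay, at which 2 of the 4 values shown sit.

Compound 2 is the only ether shown, and it remains unclear whether the ester link or the ring matters more. Also open, from the compounds shown here alone, is how a furan-3-yl group joined through an ether, or an amine at the end of the 2-acetoxyethyl chain, would behave.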